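Moving the ring substituent in a spiro-morpholine triazine series

The source may hold more compounds than are shown below. What is called first, only, known or untested is meant among the compounds shown, and "the series" means these compounds.

The three measured compounds share one core and differ only in the aryl group at the end of the ether chain. Compound 3 `NC1=NC2(CCOCC2)N(OCCCOc2ccccc2Cl)C(N)=N1` gives 70 nM in a functional assay on HCT-116 cells (Homo sapiens) for antiproliferative activity, read by MTT assay, with a stated time of 72 h (a lower number here means a stronger inhibitor, a higher number a weaker inhibitor), the lowest number of the three. Compound 1 `NC1=NC2(CCOCC2)N(OCCCOc2cccc(Cl)c2)C(N)=N1` gives 120 nM, and the step of a 1.7-fold lower number from compound 1 to compound 3 (0.23 log units; within the scatter) lies within the scatter. Compound 2 `Cc1ccc(OCCCON2C(N)=NC(N)=NC23CCOCC3)cc1` gives 2390 nM, far off: the step of a 34-fold lower number from compound 2 to compound 3 (1.53 log units; beyond the scatter) is large.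

Compound 4 `NC1=NC2(CCOCC2)N(OCCCOc2ccc(Br)cc2)C(N)=N1` has not yet been measured. The change from compound 3 is 4-bromophenyl in place of 2-chlorophenyl on an oxygen on a saturated carbon. For the measured compounds named here, no measured step covers a bromine on the ring, so the nearest guide is compound 2, whose 4-methylphenyl is the closest measured analogue of the entering 4-bromophenyl. Because a 34-fold lower number from compound 2 to compound 3 (1.53 log units; beyond the scatter) was large, and because a 1.7-fold lower number from compound 1 to compound 3 (0.23 log units; within the scatter) showed that moving the chlorine around the ring changed little, a clear rise in the number is expected for compound 4, though a bromine need not behave like a methyl, so the range is wide. Compound 4 is therefore estimated at 700 nM in this assay, between 150 nM and 3000 nM, a step of a 10-fold higher number from compound 3 to compound 4 (1.00 log units; beyond the scatter).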

Compound 4, half-maximal inhibitory concentration: 320 nM
For compound 4 the middle estimate is 2.2-fold (0.34 log units) above the measured one; the measured number falls inside the stated range.
By their numbers in this assay, from the lowest: compounds 3 and 1 (each within the scatter of the next); then compound 4; then compound 2.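

The 4-bromophenyl group does not read like either chlorophenyl group at this place on an oxygen on a saturated carbon in this assay: the data show a 4.6-fold higher number from compound 3 to compound 4 (0.66 log units; beyond the scatter) and a 2.7-fold higher number from compound 1 to compound 4 (0.43 log units; beyond the scatter), both modest steps. Bromo in place of methyl on an aromatic carbon also moves the number on its own, with a 7.5-fold lower number from compound 2 to compound 4 (0.87 log units; beyond the scatter), so 4-bromophenyl and 4-methylphenyl are not equivalent here, and compound 4 falls short of the large gap seen for compound 2. The steps from the two chlorophenyl compounds change the halogen and its place on the ring together, so they cannot show which of the two changes accounts for the higher number. Nothing in the available data bears on why these aryl groups differ.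

The compounds shown leave open whether a 4-chlorophenyl group would sit with the chlorophenyl compounds or with compound 4, which would separate the halogen from its place on the ring. They also leave open how a methoxy group or a nitrile on the ring, or a longer chain carrying the aryl group, would read.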